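The compounds below may be only part of what the source reports. "The series", "measured", "known", "first", "only" and "open" are said of these compounds alone.

Measured compounds:
Compound 1, `CCCc1cc(N)c2cc(NC(=O)/C=C/c3ccc(SC)cc3)ccc2n1`: in an assay on isolated protein for displacement of a labelled ligand from melanin-concentrating hormone receptor 1 (Homo sapiens) (a higher number here means a weaker inhibitor, a lower number a stronger inhibitor), compound 1 gives 9 nM.
Compound 2, `CCCc1cc(N)c2cc(NC(=O)/C=C/c3ccc(Cl)c(Cl)c3)ccc2n1`: in this assay compound 2 gives 60 nM.
Compound 3, `CCCc1cc(N)c2cc(NC(=O)/C=C/c3ccc(Br)cc3)ccc2n1`: in this assay compound 3 gives 4 nM.

Compound 3 carries the lowest number of the three; the step of a 2.3-fold lower number from compound 1 to compound 3 (0.35 log units; beyond the scatter) and the step of a 15-fold lower number from compound 2 to compound 3 (1.18 log units; beyond the scatter) both fall outside the scatter, so compound 3 is the strongest inhibitor of this set. The next compound, compound 4, has the structure `CCCc1cc(N)c2cc(NC(=O)/C=C/c3ccc(C(C)C)cc3)ccc2n1`. It differs from compound 3 in one place: isopropyl in place of bromo on an aromatic carbon.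

Within the data shown here, only one measured step touches the same aromatic carbon: a 2.3-fold lower number from compound 1 to compound 3 (0.35 log units; beyond the scatter), where methylsulfanyl gave way to bromo. The step of a 6.7-fold higher number from compound 1 to compound 2 (0.82 log units; beyond the scatter) and the step of a 15-fold lower number from compound 2 to compound 3 (1.18 log units; beyond the scatter) concern a different pattern of substitution and bear less directly on the change to isopropyl. None of these steps shows what a three-carbon group at this position does, so the direction is uncertain; a small shift toward a higher number, at the edge of the scatter, seems the most likely outcome, given that compound 3 holds the lowest value with 4 nM.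

Compound 4 is therefore expected to give about 8 nM in this assay, within a range of 3 nM to 25 nM. The step of a 2.0-fold higher number from compound 3 to compound 4 (0.30 log units; within the scatter) is the estimated change from compound 3 to compound 4.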

Compound 4, half-maximal inhibitory concentration: 2.9 nM
For compound 4 the middle estimate is 2.8-fold (0.44 log units) above the measured one, and the stated range ends above it.
By their numbers in this assay, from the lowest: compounds 4 and 3 (each within the scatter of the next); then compound 1; then compound 2.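

In this assay, the step of a 1.4-fold lower number from compound 3 to compound 4 (0.14 log units; within the scatter) shows that isopropyl, with its 3 heavy atoms, can take the place of the single bromine atom on this aromatic carbon, para to a large group, with no difference beyond the scatter. Isopropyl also keeps an advantage over methylsulfanyl that lies beyond the scatter, a 3.1-fold lower number from compound 1 to compound 4 (0.49 log units; beyond the scatter), as bromo did, and the gap to the 3,4-dichlorophenyl compound is large, a 21-fold lower number from compound 2 to compound 4 (1.32 log units; beyond the scatter). Nothing in the available data accounts for bromo and isopropyl giving values that cannot be told apart at this position.

The compounds shown leave open how far this holds for other groups on the same aromatic carbon, such as tert-butyl, a longer chain such as n-hexyl, an amine or a carboxylic acid. They also leave open what 4-chlorophenyl would give, which would separate the effect of a single chlorine atom from that of the 3,4-dichlorophenyl pattern.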